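The source may report more compounds than this note shows. Statements on the series, on what has been measured and on what is new or still open speak of the compounds shown alone.

The study sets compound 1 `CCCCCCNc1[nH]ccc2ncnc1-2` beside compound 2 `[N-]=[N+]=Nc1nccc2c1ncn2C1O[C@H](CO)[C@@H](O)[C@H]1O` and an unmeasured compound 3 `CNc1[nH]ccc2ncnc1-2`. In a functional assay (Homo sapiens) for inhibition of Nucleic Acid, tested at 100 uM (a lower number here means less inhibition, a higher number more inhibition at the concentration tested (going by the name of the read-out)), compound 1 gives 53%, the higher of the two values recorded. In this assay compound 2 gives 4%, a reading that lies beyond the scatter below compound 1. Compound 2 shares no single-point change with compound 1, so its number can only be set next to that of compound 1 without attributing the gap to any one change.

Compound 3 differs from compound 1 as follows: hydrogen in place of pentyl on a saturated chain carbon bound to a nitrogen on an aromatic ring. For the measured compounds named here, no measured pair shows the effect of this change, so the expectation rests on compound 1 alone. A moderate fall beyond the scatter is expected, with a number 23 percentage points lower from compound 1 to compound 3 (beyond the scatter) as the estimated step from compound 1 to compound 3. Compound 3 is therefore expected to give 30% in this assay, within a range of 8% to 52%.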

Compound 3, a percentage reported as inhibition, at one concentration (the size of the read-out at that concentration, not a potency): 18%
Compound 3: the middle estimate sits 12 percentage points above what was measured, and the stated range covers the measured number.
By their numbers in this assay, from the lowest: compound 2; then compound 3; then compound 1.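

In this assay, hydrogen in place of pentyl on a saturated chain carbon bound to a nitrogen on an aromatic ring gives a number 35 percentage points lower from compound 1 to compound 3 (beyond the scatter). For the compounds shown here, this pair is the one comparison in which a difference in inhibition can be tied to a single place, with the shared core unchanged, and it shows that the reading at this position is sensitive to the pentyl group. No accompanying measurement offers an explanation for this step.

Only pentyl and hydrogen are shown at this place, so how the reading changes with a shorter chain such as ethyl, a longer chain such as octyl, or a chain ending in an amine or a carboxylic acid remains open. On these data alone, whether the same change would have a similar effect on a different core also remains open.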